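Methyl in Place of Phenyl: Expected Cytotoxicity of Compound 3

The source may report more compounds than this note shows. Statements on the series, on what has been measured and on what is new or still open speak of the compounds shown alone.

Compound 1 `O=C(Nc1nnc(-c2cccc(O)c2O)s1)c1ccccc1` was examined in an ADME assay on MRC5 cells (Homo sapiens) for cytotoxicity, read by MTT assay, with a stated time of 72 h (on this read-out higher numbers stand for weaker inhibition and lower numbers for stronger inhibition), where compound 1 gives 23200 nM. A related amide, compound 2 `O=C(Nc1nnc(-c2ccc(O)c(O)c2)s1)c1ccc(Cl)cc1`, was run in the same setting, and in this assay compound 2 gives 30600 nM. These two values lie within the usual scatter of each other, so compound 1 cannot be set apart from compound 2 on the numbers at hand. Compound 3 `CC(=O)Nc1nnc(-c2cccc(O)c2O)s1` differs from compound 1 by methyl in place of phenyl on a carbonyl carbon. Going by the values given here, no measured pair shows what this change does, so the step from compound 1 to compound 3 has to be expected rather than read from data. The expected step of a 1.3-fold higher number from compound 1 to compound 3 (0.11 log units; within the scatter) is judged small, leaning toward a weaker effect, and may not exceed the scatter. Compound 3 is therefore estimated at 30000 nM in this assay, with a range from 12000 nM to 80000 nM.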

Compound 3, half-maximal inhibitory concentration: 156000 nM
Compound 3: the middle estimate sits 5.2-fold (0.72 log units) below what was measured; the whole stated range lies below it.
By their numbers in this assay, from the lowest: compounds 1 and 2 (each within the scatter of the next); then compound 3.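

Methyl in place of phenyl on a carbonyl carbon gives a 6.7-fold higher number from compound 1 to compound 3 (0.83 log units; beyond the scatter) in this assay and so moves the number clearly toward weaker inhibition. Going by these compounds alone, the earlier compounds offered no step between them, so this is the first sign that the group on this carbonyl carbon matters on this read-out, and that keeping the phenyl goes with the stronger inhibition of the two. Nothing at hand accounts for the size of this step.

A single step cannot tell whether the loss of the aromatic ring or the loss of carbon atoms goes with the change, and a cyclohexyl group or a longer chain such as butyl on the same carbonyl carbon would separate the two. As far as these compounds go, it also remains open whether the same change would give a similar step on the core of compound 2.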